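The source may report more compounds than this note shows. Statements on the series, on what has been measured and on what is new or still open speak of the compounds shown alone.

Measured in an ADME assay on CEM-SS cells (Homo sapiens) for cytotoxicity, read by XTT assay; on this read-out higher numbers stand for lower toxicity in this test and lower numbers for higher toxicity in this test:

Compound 1 `O=C(NO)c1cc2ccn(Cc3cccc(Cl)c3F)c2cn1`: > 320000 nM (a limit)
Compound 2 `O=C(NO)c1cc2ccn(Cc3c(F)ccc(Cl)c3F)c2cn1`: > 1000 nM (a limit)

For the measured compounds named here, neither compound has an exact number in this assay so far. Compound 1 stands only at a limit of > 320000 nM in this test. Compound 2 likewise has only a limit of > 1000 nM in this test. Going by the values given here, the one measured step is a step that the two limits leave unreadable from compound 1 to compound 2 and so offers no size to carry forward.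

Compound 3 `O=C(NO)c1cc2ccn(Cc3cccc(Cl)c3Cl)c2cn1` has not yet been measured. It differs from compound 1 by chloro in place of fluoro on an aromatic carbon, ortho to a chloro group chloro in place of fluoro on an aromatic carbon and the rest of the structure is shared. With no readable step as a guide, the expectation rests on compound 1 alone, whose limit of > 320000 nM is the only anchor. A modest move toward lower numbers is expected, and the estimated change is an at least 3.2-fold lower number from compound 1 to compound 3 (0.50 log units; beyond the scatter) with wide uncertainty. For compound 3 the expected value is 100000 nM within an estimated range of 5000 nM to 320000 nM and the test may well report only a limit again.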

Compound 3, half-maximal cytotoxic concentration: > 320000 nM
Compound 3 was reported as a limit; the forecaster's own chance of this, stated with the estimate: 75%; at least 3.2-fold (0.50 log units) between middle value and limit.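

In this assay, compound 1 and compound 3 are both reported only as limits, and no size can be read for the change of fluoro to chloro between them. The compounds shown leave open where the exact values of compound 1 and compound 3 lie, and whether this change shifts the read-out at all.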